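A few compounds are considered here, and "the series" means these few. Any claim that something is new, unique, unknown or untested is made for them only; others in the source may bear on it.

Working notes on the series.

Compound 1 `COc1cc2c(Oc3ccc(NC(=O)c4nn(-c5ccccc5Br)c(=O)c5ccccc45)cc3F)ccnc2cc1OCCCN1CCCC1` gives 410 nM in a functional assay on MKN-45 cells (Homo sapiens) for cytotoxicity, read by MTT assay, with a stated time of 72 h; a higher number here means a weaker inhibitor, a lower number a stronger inhibitor. Compound 2 `COc1cc2c(Oc3ccc(NC(=O)c4nn(-c5ccc([N+](=O)[O-])cc5)c(=O)c5ccccc45)cc3F)ccnc2cc1OCCCN1CCCC1` differs from compound 1 in one place, (4-nitrophenyl in place of 2-bromophenyl on an aromatic nitrogen), and in this assay compound 2 gives 1620 nM, a step of a 4.0-fold higher number from compound 1 to compound 2 (0.60 log units; beyond the scatter). Compound 3 `COc1cc2c(Oc3ccc(NC(=O)c4nn(-c5ccccc5Br)c(=O)c5ccccc45)cc3F)ccnc2cc1OCCCN1CCN(C)CC1` differs from compound 1 by 4-methylpiperazin-1-yl in place of pyrrolidin-1-yl on a saturated chain carbon, three bonds along the chain from an oxygen on an aromatic ring; in this assay compound 3 gives 400 nM, and the step of a 1.0-fold lower number from compound 1 to compound 3 (0.01 log units; within the scatter) lies within the scatter, so compound 1 and compound 3 are not separated here.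

Compound 4 `COc1cc2c(Oc3ccc(NC(=O)c4nn(-c5ccc([N+](=O)[O-])cc5)c(=O)c5ccccc45)cc3F)ccnc2cc1OCCCN1CCN(C)CC1` has not yet been measured. It stands to compound 3 as compound 2 stands to compound 1: the change is 4-nitrophenyl in place of 2-bromophenyl on an aromatic nitrogen, the same kind of change, with both place descriptions reading alike. The expectation for the step from compound 3 to compound 4 in this assay is a 4.0-fold higher number from compound 3 to compound 4 (0.60 log units; beyond the scatter), resting on the step of a 4.0-fold higher number from compound 1 to compound 2 (0.60 log units; beyond the scatter) seen for the same change on the core of compound 1 and on compound 3 giving 400 nM. Compound 4 is therefore estimated at 1600 nM, with a range of 800 nM to 3300 nM.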

Compound 4, half-maximal inhibitory concentration: 1320 nM
Estimate against measurement, compound 4: 1.2-fold (0.08 log units) above; the range from low to high includes it.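

In this assay, the exchange of 2-bromophenyl for 4-nitrophenyl carries over to the core bearing 4-methylpiperazin-1-yl, with a step of a 3.3-fold higher number from compound 3 to compound 4 (0.52 log units; beyond the scatter), and it agrees with the earlier step: the same change on two cores in this assay, a 4.0-fold higher number (0.60 log units; beyond the scatter) from compound 1 to compound 2 and a 3.3-fold higher number (0.52 log units; beyond the scatter) from compound 3 to compound 4, 1.2-fold (0.08 log units) apart, within the scatter of two such steps. Pyrrolidin-1-yl and 4-methylpiperazin-1-yl also remain unseparated with 4-nitrophenyl in place, with a step of a 1.2-fold lower number from compound 2 to compound 4 (0.09 log units; within the scatter), matching the 2-bromophenyl pair: the same change on two cores in this assay, a 1.0-fold lower number (0.01 log units; within the scatter) from compound 1 to compound 3 and a 1.2-fold lower number (0.09 log units; within the scatter) from compound 2 to compound 4, 1.2-fold (0.08 log units) apart, within the scatter of two such steps. The two changes therefore behave independently across these four compounds, but this does not show that the same holds for other groups or explain the size of either step.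

Still open, as far as these compounds go, is how an unsubstituted phenyl or a pyridyl on the aromatic nitrogen would behave. From the compounds shown here alone, a morpholine at the chain end is equally open.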